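The source may hold more compounds than are shown below. What is called first, only, known or untested is meant among the compounds shown, and "the series" means these compounds.

In a functional assay on SF-268 cells (Homo sapiens) for inhibition, read by sulforhodamine B assay, with a stated time of 48 h (on this read-out lower numbers stand for stronger inhibition of growth and higher numbers for weaker inhibition of growth), compound 1 `N#CCC1=C(C#N)CC(c2ccc(Br)cc2)=C(CC(=O)c2ccc(Br)cc2)O1` gives 8200 nM and compound 2 `N#CCC1=C(C#N)CC(c2ccc([N+](=O)[O-])cc2)=C(CC(=O)c2ccc([N+](=O)[O-])cc2)O1` gives 5 nM, the lower of the two numbers and far beyond the scatter. Compound 3 `N#CCC1=C(C#N)CC(c2ccc(Br)cc2)=C(CC(=O)c2ccc([N+](=O)[O-])cc2)O1` differs from compound 2 at one place, with bromo in place of nitro on an aromatic carbon. Among the compounds with values here, no single-place step between measured compounds is available, so the expectation rests on these two values alone. A clear rise beyond the scatter is expected, towards but short of the value of compound 1 at 8200 nM. The estimated change is a 40-fold higher number from compound 2 to compound 3 (1.60 log units; beyond the scatter). For compound 3 the expected value is 200 nM, with an estimated range of 20 nM to 2000 nM.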

Compound 3, concentration for 50% growth inhibition: 3 nM
Beside the measured number, compound 3's estimate is 67-fold (1.82 log units) above it; the whole stated range lies above it.
By their numbers in this assay, from the lowest: compounds 3 and 2 (each within the scatter of the next); then compound 1.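

In this assay, changing 4-nitrophenyl to 4-bromophenyl at this position leaves the number within the scatter (a 1.7-fold lower number from compound 2 to compound 3 (0.22 log units; within the scatter)), so here bromo and nitro cannot be told apart. The same two groups exchanged at the other place, with nitro in place of bromo, give a large change (a 2700-fold lower number from compound 1 to compound 3 (3.44 log units; beyond the scatter)), so among these compounds the gap rests on that other place alone. Nothing available explains why the two places differ.
Still open, going by these compounds, is whether an amine or a carboxylic acid at this position would keep the number as low.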